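From Ethoxy to Carbamoyl: Expecting the Next Measurement

The source may report more compounds than this note shows. Statements on the series, on what has been measured and on what is new or still open speak of the compounds shown alone.

Three compounds have been measured in an assay on isolated protein (strain Sprague-Dawley) for inhibition of Amine oxidase [flavin-containing] B (Rattus norvegicus), read by spectrophotometry, with a stated time of 5 min; on this read-out higher numbers stand for weaker inhibition and lower numbers for stronger inhibition:

compound 1 `CCOc1cc(=O)oc2cc(OCc3cccc(Cl)c3)ccc12`: 115 nM
compound 2 `O=c1cc(Nc2ccccc2)c2ccc(OCc3cccc(Cl)c3)cc2o1`: 9770 nM
compound 3 `CCOC(=O)c1cc(=O)oc2cc(OCc3cccc(Cl)c3)ccc12`: 417 nM

Compound 1 has the lowest number of the three, meaning the strongest inhibition. Its nearest neighbour is compound 3, reached by a change of ethoxycarbonyl in place of ethoxy on an aromatic carbon, which gives a 3.6-fold higher number from compound 1 to compound 3 (0.56 log units; beyond the scatter). The furthest is compound 2, where anilino in place of ethoxy on an aromatic carbon gives an 85-fold higher number from compound 1 to compound 2 (1.93 log units; beyond the scatter). Between those two, ethoxycarbonyl in place of anilino gives a 23-fold lower number from compound 2 to compound 3 (1.37 log units; beyond the scatter).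

The next compound is compound 4 `NC(=O)c1cc(=O)oc2cc(OCc3cccc(Cl)c3)ccc12`. Relative to compound 1 the change is carbamoyl in place of ethoxy on an aromatic carbon.

The step from compound 1 to compound 3 bears most directly on this, since it also swaps the ethoxy group at the same place for a group of three heavy atoms, and it weakened inhibition modestly. The step to compound 2 shows that a larger, ring-bearing replacement weakens inhibition far more, but carbamoyl carries no ring. A modest weakening is therefore expected, a 6.1-fold higher number from compound 1 to compound 4 (0.78 log units; beyond the scatter). Compound 4 is estimated to give 700 nM, within a range of 150 nM to 3500 nM.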

Compound 4, half-maximal inhibitory concentration: 234 nM
Estimate against measurement, compound 4: 3.0-fold (0.48 log units) above; measured number inside the range.
By their numbers in this assay, from the lowest: compound 1; then compounds 4 and 3 (each within the scatter of the next); then compound 2.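

In this assay, carbamoyl in place of ethoxy at the place opposite the ring oxygen gives a 2.0-fold higher number from compound 1 to compound 4 (0.31 log units; beyond the scatter) and so costs little, even though carbamoyl brings a hydrogen-bond donor that ethoxy lacks. Compound 4 also sits far from the anilino compound, with a 42-fold lower number from compound 2 to compound 4 (1.62 log units; beyond the scatter) showing that among these compounds the large loss belongs to the ring-bearing replacement alone, not to every swap of ethoxy at this place. The two carbonyl-linked groups cannot be told apart, since amino in place of ethoxy on the carbonyl carbon gives a 1.8-fold lower number from compound 3 to compound 4 (0.25 log units; within the scatter) and that step lies within the scatter, so compounds 3 and 4 stand level in this assay.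

The compounds shown leave open whether a carboxylic acid, a simple amine or a longer alkoxy chain at this place would stay as close to compound 1 as carbamoyl does. Nothing available here bears on why these groups differ as they do.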